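Sulfoxide and Nitro Changes in a Quinazoline Cytotoxicity Series

This account rests on a few compounds, and the source may have more. Where it says the series, first, only, none or still open, it means among the compounds named here.

The three measured compounds share one core and differ at two points. Compound 1 `COc1cc2nc(SCC(=O)Nc3ccc([N+](=O)[O-])cc3)nc(Nc3c(C)cc(/C=C/C#N)cc3C)c2cc1OC` and compound 2 `COc1cc2nc(SCC(=O)Nc3ccc(C(F)(F)F)cc3)nc(Nc3c(C)cc(/C=C/C#N)cc3C)c2cc1OC` carry a sulfide linker; compound 3 `COc1cc2nc([S+]([O-])CC(=O)Nc3ccc(C(F)(F)F)cc3)nc(Nc3c(C)cc(/C=C/C#N)cc3C)c2cc1OC` carries a sulfoxide instead, and the difference between the core of compound 3 and that of compound 2 is not broken down here. In an ADME assay on MT4 cells (Homo sapiens) for cytotoxicity, read by MTT assay, with a stated time of 5 days (a higher number here means that more compound is tolerated, a lower number that less compound is tolerated), compound 1 gives only a limit, > 219000 nM. In this assay compound 2 also gives only a limit, > 211000 nM. For the measured compounds named here, compound 3 is the one compound with a number in this assay, giving 52200 nM.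

The change from compound 2 to compound 1 is nitro in place of trifluoromethyl on an aromatic carbon. Its size is a step that the two limits leave unreadable from compound 2 to compound 1, because the limit of > 211000 nM in this assay, at which 1 of the 3 values shown sits, and the limit of > 219000 nM in this assay, at which 1 of the 3 values shown sits, both mark limits rather than numbers.

Compound 4 `COc1cc2nc([S+]([O-])CC(=O)Nc3ccc([N+](=O)[O-])cc3)nc(Nc3c(C)cc(/C=C/C#N)cc3C)c2cc1OC` has not yet been measured. It differs from compound 3 by nitro in place of trifluoromethyl on an aromatic carbon, the same change as from compound 2 to compound 1, made on the sulfoxide core. Since the earlier step cannot be read, the expected step from compound 3 to compound 4 is taken as a 1.0-fold lower number from compound 3 to compound 4 (0.00 log units; within the scatter), a small one, resting on the value of compound 3 in this assay, 52200 nM. Compound 4 is therefore estimated at 52000 nM, with a wide range from 15000 nM to 160000 nM.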

Compound 4, half-maximal cytotoxic concentration: 189000 nM
Compound 4: the middle estimate sits 3.6-fold (0.56 log units) below what was measured; measured number above the stated range.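

On the sulfoxide core in this assay, nitro in place of trifluoromethyl on an aromatic carbon gives a 3.6-fold higher number from compound 3 to compound 4 (0.56 log units; beyond the scatter), so on this core the nitro compound is the one tolerated at the higher concentration. On the sulfide core, the same change from compound 2 to compound 1 has no readable size, and compound 2 gives only a limit of the assay: the limit of > 211000 nM in this assay, at which 1 of the 4 values shown sits. Compound 1 also gives only a limit, so this single readable step shows what the change does on the sulfoxide core but not whether it carries over from the sulfide core with a similar size, a different size or no effect at all: the limit of > 219000 nM in this assay, at which 1 of the 4 values shown sits.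

The compounds shown leave open whether the step on the sulfoxide core would recur on a third core, such as one with a sulfone in place of the sulfoxide. They also leave open how an amine or a carboxylic acid in place of nitro or trifluoromethyl, on the same aromatic carbon, would read in this assay, so no general rule for this position can be drawn from these compounds.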